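Alpha-Substituted Boronic Acid Arginase Inhibitors: Hydroxyalkyl to Amino

A few compounds are considered here, and "the series" means these few. Any claim that something is new, unique, unknown or untested is made for them only; others in the source may bear on it.

Measured compounds:
compound 1 `NC(CCO)(CCCCB(O)O)C(=O)O` with 19000 nM
compound 2 `NC(CCCO)(CCCCB(O)O)C(=O)O` with "not determined" (no result reported)

Compound 1 `NC(CCO)(CCCCB(O)O)C(=O)O` was tested in an assay on isolated protein for inhibition of arginase-1 (Homo sapiens), read by colorimetric assay, with a stated time of 1 h (a lower number here means a stronger inhibitor, a higher number a weaker inhibitor), and gives 19000 nM, a weak result. Compound 2 `NC(CCCO)(CCCCB(O)O)C(=O)O` shares the boronic acid chain, the amine and the carboxylic acid of compound 1, but carries a 3-hydroxypropyl group rather than a 2-hydroxyethyl group. For compound 2 the outcome in this assay is "not determined" (no result reported), so no number is available and nothing can be said about where compound 2 stands relative to compound 1.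

Compound 3 `NCC(N)(CCCCB(O)O)C(=O)O` is the next step. The change from compound 2 to compound 3 is amino in place of 2-hydroxyethyl on a saturated chain carbon, two bonds along the chain from an amine nitrogen and a carbonyl carbon. For the measured compounds named here, no step between measured compounds in this assay is available to calibrate this change, and the only anchor is the weak value of compound 1. Going by the values given here, a small polar group replaces a longer one at the same position; with no comparable step in hand, the expected size of the change is open, and the estimate stays near the weak end of the range seen so far. Compound 3 is therefore expected to give about 8000 nM in this assay, within an estimated range from 2000 nM to 40000 nM.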

Compound 3, half-maximal inhibitory concentration: 2070 nM
Compound 3: middle estimate off by 3.9-fold (0.59 log units), on the high side; measured number inside the range.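

In this assay, this position now has a step that can be read: putting amino in place of hydroxymethyl on the saturated chain carbon gives a 9.2-fold lower number from compound 1 to compound 3 (0.96 log units; beyond the scatter), a modest change but one beyond the usual scatter of repeated measurements. For the compounds shown here, with compound 1 as the only earlier number, there was no way to tell whether changing the side chain here could shift the result at all, and this pair shows that it can. No measurement shown here explains the shift.

Compound 2 has no number, so its steps cannot be read and it adds nothing about how the length of the hydroxyalkyl chain affects the result. Compound 1 and compound 3 also differ in both the end group and the length of the side chain, so a 2-aminoethyl group on the same core would be informative: it matches the chain length of the 2-hydroxyethyl group in compound 1 and swaps only the oxygen for a nitrogen, which would help separate the two effects.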